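Swapping an Ether Tail for a Thioether Tail

The source may report more compounds than this note shows. Statements on the series, on what has been measured and on what is new or still open speak of the compounds shown alone.

Three measured compounds share one core. Compound 1 `Cc1nc(C)c([C@H](OC(C)(C)C)C(=O)O)c(N2CCC(C)(C)CC2)c1-c1ccc(Oc2ccccc2)cc1` carries a phenyl on an oxygen on an aromatic ring. In a toxicity assay on MT2 cells (Homo sapiens) for cytotoxicity, read by XTT assay, with a stated time of 4 days (a lower number here means that less compound is tolerated, a higher number that more compound is tolerated), compound 1 gives >= 20000 nM, which is a limit of the assay rather than a number. Compound 2 `Cc1nc(C)c([C@H](OC(C)(C)C)C(=O)O)c(N2CCC(C)(C)CC2)c1-c1ccc(OCCc2ccc(Cl)cc2)cc1` has 2-(4-chlorophenyl)ethyl in place of that phenyl. Compound 2 gives >= 33500 nM, again a limit. Compound 3 `Cc1nc(C)c([C@H](OC(C)(C)C)C(=O)O)c(N2CCC(C)(C)CC2)c1-c1ccc(OCCc2cc(F)ccc2F)cc1` has 2-(2,5-difluorophenyl)ethyl there. Compound 3 gives >= 33500 nM, also a limit. All three values sit at limits: one at the limit of >= 20000 nM in this assay, at which 1 of the 3 values shown sits, and two at the limit of >= 33500 nM in this assay, at which 2 of the 3 values shown sit. Within the data shown here, the steps a step that the two limits leave unreadable from compound 1 to compound 2, a step that the two limits leave unreadable from compound 1 to compound 3 and a step that the two limits leave unreadable from compound 2 to compound 3 cannot be read, so compound 3 stands only at a limit, with no measured step to gauge it against.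

Compound 4 `Cc1nc(C)c([C@H](OC(C)(C)C)C(=O)O)c(N2CCC(C)(C)CC2)c1-c1ccc(SCCc2ccc(F)cc2)cc1` differs from compound 3 by (2-(4-fluorophenyl)ethyl)sulfanyl in place of 2-(2,5-difluorophenyl)ethoxy on an aromatic carbon. Among the measured compounds shown here, no measured step bears on this change, so no direction can be read. The best expectation is that compound 4 again shows a limit, an estimated step of a number no higher from compound 3 to compound 4 (the limit leaves the size open). Compound 4 is therefore expected to give about 33500 nM, within 20000 nM to 50000 nM.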

Compound 4, half-maximal cytotoxic concentration: >= 32000 nM
Compound 4 gave a limit, no number; the forecaster's own chance of this, stated with the estimate: 85%; the middle value lies beyond the limit too.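

In this assay compound 4 gives >= 32000 nM, which is a limit of the assay and not a number. Its steps from compound 1, compound 2 and compound 3 therefore cannot be read. The compounds shown leave open the concentration at which any of the four harms these cells, and whether the thioether tail differs from the ether tails.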